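A few compounds are considered here, and "the series" means these few. Any claim that something is new, unique, unknown or untested is made for them only; others in the source may bear on it.

Compound 1 `NS(=O)(=O)c1ccc(N2N=C(c3ccc(OCc4ccccc4)cc3)CC2c2ccc(F)cc2)cc1` gives the highest of three numbers in an ADME assay on BHK-21 cells (Mesocricetus auratus) for cytotoxicity, read by MTT assay, with a stated time of 72 h (a lower number here means that less compound is tolerated, a higher number that more compound is tolerated), with 60000 nM and lies well above compound 2 `NS(=O)(=O)c1ccc(N2N=C(c3ccc(Oc4ccccc4)cc3)CC2c2ccc(F)cc2)cc1` at 8000 nM and compound 3 `Cc1ccccc1C1CC(c2ccc(Oc3ccccc3)cc2)=NN1c1ccc(S(N)(=O)=O)cc1` at 7000 nM on this scale. Compound 4 `NS(=O)(=O)c1ccc(N2N=C(c3ccc(OCc4ccccc4)cc3)CC2c2cccc(F)c2)cc1` keeps the core of compound 1 and carries 3-fluorophenyl in place of 4-fluorophenyl on a saturated ring carbon. The closest evidence comes from that same carbon, where 2-methylphenyl in place of 4-fluorophenyl gave a 1.1-fold lower number from compound 2 to compound 3 (0.06 log units; within the scatter) and so no real shift. The larger step of a 7.5-fold lower number from compound 1 to compound 2 (0.88 log units; beyond the scatter) came with phenyl in place of benzyl on an oxygen, a part that compound 4 leaves unchanged. Within the data shown here, no measured step moves a fluorine, so the evidence is thin, and no step beyond the scatter is expected in this assay here. The estimated change is small (a 1.2-fold lower number from compound 1 to compound 4 (0.08 log units; within the scatter)). Compound 4 is expected at 50000 nM (estimated range 20000 nM to 100000 nM).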

Compound 4, half-maximal cytotoxic concentration: 9000 nM
Compound 4: middle estimate off by 5.6-fold (0.74 log units), on the high side, outside the stated range (below it).
By their numbers in this assay, from the lowest: compounds 3, 2 and 4 (each within the scatter of the next); then compound 1.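

Moving the fluorine alone, with the same atoms on the same ring, gives a 6.7-fold lower number from compound 1 to compound 4 (0.82 log units; beyond the scatter) in this assay. The aryl group on this saturated ring carbon therefore matters in this assay, which the earlier within-scatter swap of 2-methylphenyl for 4-fluorophenyl, made with phenyl rather than benzyl on the oxygen, did not show. Nothing available here explains this shift. On these data alone, whether the same fluorine move has any effect with phenyl on that oxygen remains open. So does the outcome of replacing the fluorine with an amine or a carboxylic acid.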